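The compounds below may be only part of what the source reports. "The series", "measured", "known", "first", "only" and "open" are said of these compounds alone.

Measured so far in a functional assay on GBM1 cells (Homo sapiens) for antiproliferative activity, read by WST assay, with a stated time of 72 h; a higher number here means a weaker inhibitor, a lower number a stronger inhibitor:
compound 1, `O=C(Nc1ccccc1F)Nc1cc2ncncc2cc1OCc1cccc(F)c1`, 8000 nM
compound 2, `O=C(Nc1ccccc1F)Nc1cc2ncncc2cc1OCc1ccccc1F`, 4200 nM
compound 3, `O=C(Nc1ccc(Cl)c(Cl)c1)Nc1cc2ncncc2cc1OCc1cccc(F)c1`, 2100 nM

Compound 3 gives the lowest of the three numbers in this assay. Against compound 2 the gap lies within the scatter, so no order between these two can be read; against compound 1 the gap is beyond the scatter, as a 3.8-fold lower number from compound 1 to compound 3 (0.58 log units; beyond the scatter) shows, a modest step.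

Compound 4, `O=C(Nc1ccc(Cl)c(Cl)c1)Nc1cc2ncncc2cc1OCc1ccccc1F`, has the same atoms as compound 3, joined differently: 2-fluorophenyl in place of 3-fluorophenyl on a saturated chain carbon bound to an oxygen on an aromatic ring. Among the compounds with values here, the one measured step of the same kind is a 1.9-fold lower number from compound 1 to compound 2 (0.28 log units; within the scatter), a drop that stays within the scatter. Within the data shown here, that is the only comparison that bears on the change, and it does not establish a real difference between the two fluorophenyl placements.

The expectation for compound 4 in this assay is therefore a number close to that of compound 3, estimated at 1400 nM with a range of 600 nM to 3500 nM. This estimate means an expected step of a 1.5-fold lower number from compound 3 to compound 4 (0.18 log units; within the scatter), leaning slightly toward a lower number because of a 1.9-fold lower number from compound 1 to compound 2 (0.28 log units; within the scatter), but with no step beyond the scatter expected.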

Compound 4, half-maximal inhibitory concentration: 4100 nM
Compound 4: middle estimate off by 2.9-fold (0.47 log units), on the low side; measured number above the stated range.
By their numbers in this assay, from the lowest: compounds 3, 4, 2 and 1 (each within the scatter of the next, the first and the last beyond it).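

In this assay, with 3,4-dichlorophenyl on the amide-type nitrogen, 2-fluorophenyl in place of 3-fluorophenyl on a saturated chain carbon bound to an oxygen on an aromatic ring gives a 2.0-fold higher number from compound 3 to compound 4 (0.29 log units; within the scatter), so this change does not carry the same sign or size across the two cores: the same change on two cores in this assay, a 1.9-fold lower number (0.28 log units; within the scatter) from compound 1 to compound 2 and a 2.0-fold higher number (0.29 log units; within the scatter) from compound 3 to compound 4, 3.7-fold (0.57 log units) apart, beyond the scatter of two such steps. Read the other way, 3,4-dichlorophenyl in place of 2-fluorophenyl on an amide-type nitrogen gives a 1.0-fold lower number from compound 2 to compound 4 (0.01 log units; within the scatter) when the ether side carries 2-fluorophenyl, and the gain seen with 3-fluorophenyl does not carry over: the same change on two cores in this assay, a 3.8-fold lower number (0.58 log units; beyond the scatter) from compound 1 to compound 3 and a 1.0-fold lower number (0.01 log units; within the scatter) from compound 2 to compound 4, 3.7-fold (0.57 log units) apart, beyond the scatter of two such steps. The two places therefore do not add independently in these four compounds, although each single step from compound 4 lies within the scatter and the non-additivity is visible only in the gap between paired steps.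

Within the data shown here, whether this coupling holds beyond one pair of groups at each place remains open, since four compounds form only a single square of changes. Also open, as far as these compounds go, is how an unsubstituted phenyl, a pyridine ring or a carboxylic acid on the saturated chain carbon would behave with either group on the amide-type nitrogen.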